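The source may hold more compounds than are shown below. What is called first, only, known or untested is meant among the compounds shown, and "the series" means these compounds.

Compound 1 `O=C(Nc1cccc(N2CCCC2=O)c1)C1CCCN(C(=O)c2cc(C(F)(F)F)cc(C(F)(F)F)c2)C1` serves as the reference point of the series. In an ADME assay on PC-3 cells (Homo sapiens) for cytotoxicity, read by WST assay, tested at 100 uM (a lower number here means less inhibition, a higher number more inhibition at the concentration tested (going by the name of the read-out)), compound 1 gives 0%. Compound 2 `O=C(Nc1ccc(Cl)cc1)C1CCCN(C(=O)c2cccc([N+](=O)[O-])c2)C1` gives 0% in this assay, so compound 1 and compound 2 are level at the digits recorded and together the lowest of the three numbers in hand. Compound 3 `O=C(Nc1cccc(OCCc2ccccn2)c1)C1CCCN(C(=O)c2cc(C(F)(F)F)cc(C(F)(F)F)c2)C1`, which carries 2-(pyridin-2-yl)ethoxy in place of 2-oxopyrrolidin-1-yl on an aromatic carbon, gives 5% in this assay; the step of a number 5 percentage points higher from compound 1 to compound 3 (within the scatter) lies within the scatter. For the measured compounds named here, compound 2 differs from compound 1 in more than one place, so no single step is drawn between them; their two values simply coincide.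

Compound 4 `O=C(c1ccccc1)c1cccc(NC(=O)C2CCCN(C(=O)c3cc(C(F)(F)F)cc(C(F)(F)F)c3)C2)c1` is not yet measured. It differs from compound 1 by benzoyl in place of 2-oxopyrrolidin-1-yl on an aromatic carbon. Going by the values given here, the only measured step that bears on this change is the exchange at the same aromatic carbon, a number 5 percentage points higher from compound 1 to compound 3 (within the scatter), which stayed within the scatter. Nothing measured speaks to benzoyl itself. With all three numbers in hand sitting at or near the bottom of the scale, the expectation for compound 4 in this assay is a step of a number 3 percentage points higher from compound 1 to compound 4 (within the scatter), that is, none beyond the scatter. Compound 4 is accordingly estimated at 3%, with a range from 0% to 15%.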

Compound 4, a percentage reported as inhibition, at one concentration (the size of the read-out at that concentration, not a potency): 0%
Beside the measured number, compound 4's estimate is 3 percentage points above it, within the range that was stated.
By their numbers in this assay, from the lowest: compounds 1, 2, 4 and 3 (each within the scatter of the next).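

At the aromatic carbon meta to a large group, benzoyl in place of 2-oxopyrrolidin-1-yl gives no change at the digits printed from compound 1 to compound 4 (within the scatter) in this assay, so an entering six-membered aromatic ring of carbon only leaves the read-out where the five-membered non-aromatic ring stood. Benzoyl in place of 2-(pyridin-2-yl)ethoxy at the same carbon gives a number 5 percentage points lower from compound 3 to compound 4 (within the scatter), which means that three different groups at this position, in compound 1, compound 3 and compound 4, now lie within the scatter of one another, and none of the three goes against that. No supporting data bear on why these numbers sit as they do, and the series offers no explanation for them.

Open, on these data alone, is whether a group of another kind at this carbon, such as a carboxylic acid or a primary amine, would give a step beyond the scatter in this assay. Also open, as far as these compounds go, is whether any change elsewhere on the shared core, for example a carboxylic acid in place of one trifluoromethyl group, would move the number, since the three steps in hand all concern this one position.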